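The source may report more compounds than this note shows. Statements on the series, on what has been measured and on what is new or still open speak of the compounds shown alone.

In a functional assay on KG-1 cells (Homo sapiens) for cytotoxicity, read by luminescence and CellTiter-Glo, with a stated time of 3 days (on this read-out lower numbers stand for stronger inhibition and higher numbers for weaker inhibition), compound 1 (`O=C(Nc1ccc(Cl)cc1Cl)c1cc(F)ccc1O`) gives 850 nM, and compound 2 (`N#Cc1ccc(NC(=O)c2ccc3cccnc3c2O)c(F)c1`) gives 3260 nM. Compound 2 therefore holds the higher of the two numbers and is the weaker inhibitor, and the gap between them lies beyond the usual scatter. The two compounds differ in more than one place, so this gap says nothing about any single change.

Compound 3 (`N#Cc1ccc(NC(=O)c2ccc3cccnc3c2O)cc1`) has not yet been measured. It differs from compound 2 in one place, with hydrogen in place of fluoro on an aromatic carbon, ortho to a large group and meta to a cyano group (hydrogen in place of fluoro on an aromatic carbon). Within the data shown here, no measured pair shows this change directly, so the expectation is cautious, with no shift beyond the scatter in this assay and no firm direction. The expected step of a 1.1-fold lower number from compound 2 to compound 3 (0.04 log units; within the scatter) is correspondingly small. For compound 3 the estimated value is 3000 nM, with an expected range of 1200 nM to 7500 nM.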

Compound 3, half-maximal inhibitory concentration: 2320 nM
Compound 3: the middle estimate sits 1.3-fold (0.11 log units) above what was measured, and the stated range covers the measured number.
By their numbers in this assay, from the lowest: compound 1; then compounds 3 and 2 (each within the scatter of the next).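

In this assay, among these compounds, putting hydrogen in place of the fluoro gives a 1.4-fold lower number from compound 2 to compound 3 (0.15 log units; within the scatter) and is the first direct reading of this change, as compounds 1 and 2 differ in more than one place. At this aromatic carbon, ortho to a large group and meta to a cyano group, the fluoro is not needed to hold the number seen for compound 2, and the two compounds cannot be told apart in this read-out. Nothing measured here speaks to what lies behind this result.

From the compounds shown here alone, whether an amine or a methoxy group on this same carbon would move the number beyond the scatter remains open. Also open, going by these compounds, is whether the same swap would behave alike on a different core, such as that of compound 1.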